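Swapping Chloro for Bromo on a Weakly Active Core

This account rests on a few compounds, and the source may have more. Where it says the series, first, only, none or still open, it means among the compounds named here.

Two measured compounds share one core and differ only in a single halogen. Compound 1 `CN1C(=O)C2(C(C#N)=C(N)Oc3cc4oc(-c5ccccc5)cc(=O)c4c(O)c32)c2cc(Cl)ccc21` carries a chloro group, and in a functional assay on NCI-H1299 cells (Homo sapiens) for antiproliferative activity, read by MTT assay, with a stated time of 48 h (on this read-out lower numbers stand for stronger inhibition and higher numbers for weaker inhibition), compound 1 gives 11200 nM. Compound 2 `CN1C(=O)C2(C(C#N)=C(N)Oc3cc4oc(-c5ccccc5)cc(=O)c4c(O)c32)c2cc(Br)ccc21` carries a bromo group in the same position, and in this assay compound 2 gives 7610 nM. The change between them is bromo in place of chloro on an aromatic carbon, and its size is a 1.5-fold lower number from compound 1 to compound 2 (0.17 log units; within the scatter), so the two values cannot be told apart.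

Compound 3 `CCN1C(=O)C2(C(C#N)=C(N)Oc3cc4oc(-c5ccc(OC)cc5OC)cc(=O)c4c(O)c32)c2cc(Cl)ccc21` has a different core. In this assay compound 3 gives only a limit of the assay, > 50000 nM. How the core of compound 3 differs from the core of compound 1 is not broken down here.

Compound 4 `CCN1C(=O)C2(C(C#N)=C(N)Oc3cc4oc(-c5ccc(OC)cc5OC)cc(=O)c4c(O)c32)c2cc(Br)ccc21` has not yet been measured. Among the compounds with values here, it differs from compound 3 by bromo in place of chloro on an aromatic carbon, which is the same change as the one from compound 1 to compound 2: the surroundings of the position are described in identical words for both pairs.

The expectation for compound 4 therefore rests on two things. The same halogen swap on the other core gave only a 1.5-fold lower number from compound 1 to compound 2 (0.17 log units; within the scatter), a step inside the scatter. Compound 3 sits at the limit of > 50000 nM in this assay, at which 1 of the 3 values shown sits, so even a small gain would most likely leave compound 4 at the limit as well. The step from compound 3 to compound 4 is expected to be a number no higher from compound 3 to compound 4 (the limit leaves the size open). Compound 4 is estimated at 50000 nM, with a plausible range from 25000 nM to 100000 nM.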

Compound 4, half-maximal inhibitory concentration: > 50000 nM
Compound 4: only a limit was reported; the forecaster's own chance of this, stated with the estimate: 70%; the middle value lies on the limit itself.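

In this assay compound 4 gives > 50000 nM, which is a limit of the assay and not a number. Compound 3 also sits at a limit, so no step between compound 3 and compound 4 can be read: the limit of > 50000 nM in this assay, at which 2 of the 4 values shown sit.

The compounds shown leave open whether bromo in place of chloro makes any difference on the core of compound 3, as neither compound has a readable value.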